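A few compounds are considered here, and "the series" means these few. Any claim that something is new, unique, unknown or untested is made for them only; others in the source may bear on it.

Compound 1 `CCOC(=O)Nc1cc(NC(C)C(O)COc2ccccc2)c([N+](=O)[O-])c(N)n1`: 55000 nM
Compound 2 `CCOC(=O)Nc1cc(NC(C)C(O)Cc2ccccc2)c([N+](=O)[O-])c(N)n1`: 53000 nM

In a functional assay on L1210 cells (Mus musculus), with a stated time of 48 h (on this read-out higher numbers stand for weaker inhibition and lower numbers for stronger inhibition), compound 1 gives 55000 nM, which matches compound 2 within the scatter. Among the measured compounds shown here, the only measured step, a 1.0-fold lower number from compound 1 to compound 2 (0.02 log units; within the scatter), puts phenyl in place of phenoxy on a saturated chain carbon. Compound 3 `CCOC(=O)Nc1cc(NC(C)C(O)COc2ccccc2)c(N)c(N)n1` changes a different part of the molecule: amino in place of nitro on an aromatic carbon. The measured step therefore gives no direct guide to this change, so only a modest shift toward stronger inhibition is expected, with wide uncertainty. That would be an expected 1.8-fold lower number from compound 1 to compound 3 (0.26 log units; within the scatter). Compound 3 is estimated at 30000 nM, within a range of 6000 nM to 100000 nM.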

Compound 3, half-maximal inhibitory concentration: 21000 nM
Compound 3: middle estimate off by 1.4-fold (0.15 log units), on the high side; low and high end bracket the measured number.
By their numbers in this assay, from the lowest: compound 3; then compounds 2 and 1 (each within the scatter of the next).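

In this assay, amino in place of nitro on this aromatic carbon gives a 2.6-fold lower number from compound 1 to compound 3 (0.42 log units; beyond the scatter) and so moves the number by a modest step toward stronger inhibition. The change of phenyl for phenoxy on the chain stayed within the scatter, so this ring position is the first place shown to affect the read-out. No measurement here accounts for the shift.

From the compounds shown here alone, how a hydrogen, a chlorine or a methylamino group on this carbon would compare remains open. Going by these compounds, it is also open whether the same change would give a similar step on the phenyl chain of compound 2.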